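Swapping the aryl on the triazole nitrogen: compound 4

The source may hold more compounds than are shown below. What is called first, only, known or untested is meant among the compounds shown, and "the series" means these compounds.

compound 1 `Cc1cccc(-n2nncc2CN2C(=O)C3(C(C#N)=C(N)Oc4c3c3nc5ccccc5nc3c3ccccc43)c3ccccc32)c1`: 39600 nM in a functional assay on A549 cells (Homo sapiens) for antiproliferative activity, read by MTT assay, with a stated time of 48 h; a lower number here means a stronger inhibitor, a higher number a weaker inhibitor
compound 2 `N#CC1=C(N)Oc2c(c3nc4ccccc4nc3c3ccccc23)C12C(=O)N(Cc1cnnn1-c1ccc(F)cc1)c1ccccc12`: > 50000 nM, a limit of this assay
compound 3 `N#CC1=C(N)Oc2c(c3nc4ccccc4nc3c3ccccc23)C12C(=O)N(Cc1cnnn1-c1cccc(Cl)c1)c1ccccc12`: 32600 nM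

Compound 1 stands highest of the two numbers given; the nearest neighbour is a 1.2-fold lower number from compound 1 to compound 3 (0.08 log units; within the scatter). For compound 2 the assay reports only a limit, (the limit of > 50000 nM in this assay, at which 1 of the 3 values shown sits). Compound 4 `N#CC1=C(N)Oc2c(c3nc4ccccc4nc3c3ccccc23)C12C(=O)N(Cc1cnnn1-c1ccccc1Br)c1ccccc12` changes the group on the aromatic nitrogen: 2-bromophenyl in place of 3-methylphenyl on an aromatic nitrogen. For the measured compounds named here, two measured steps touch this place. The aryl swap gave an at least 1.2-fold higher number from compound 1 to compound 2 (0.10 log units; that floor lies within the scatter), the substituent swap gave a 1.2-fold lower number from compound 1 to compound 3 (0.08 log units; within the scatter), and between the two aryls there was an at least 1.5-fold lower number from compound 2 to compound 3 (0.18 log units; that floor lies within the scatter). None of these steps leaves the scatter. The expected step is therefore a 1.0-fold higher number from compound 1 to compound 4 (0.00 log units; within the scatter). Compound 4 is expected near 40000 nM, with a range from 20000 nM to 80000 nM.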

Compound 4, half-maximal inhibitory concentration: > 50000 nM
Compound 4: no number, only a limit; the forecaster's own chance of this, stated with the estimate: 35%; middle value at least 1.2-fold (0.09 log units) from the limit.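

In this assay compound 4 gives > 50000 nM, a limit and not a number. Replacing the aryl on the aromatic nitrogen gives an at least 1.2-fold higher number from compound 1 to compound 4 (0.10 log units; that floor lies within the scatter), while the comparison with the 3-chlorophenyl compound gives an at least 1.5-fold higher number from compound 3 to compound 4 (0.18 log units; that floor lies within the scatter), so neither step shows a change beyond the scatter. 2-Bromophenyl joins 4-fluorophenyl at the limit, and the step between compound 2 and compound 4 cannot be read: the limit of > 50000 nM in this assay, at which 2 of the 4 values shown sit.

On these data alone, whether any aryl at this position can move the number beyond the scatter remains open. Also open, as far as these compounds go, is what an amine or a carboxylic acid on the phenyl ring, or cyclohexyl in place of the aryl, would give.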